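Azole swaps on the dioxolane arm of the series

A few compounds are considered here, and "the series" means these few. Any claim that something is new, unique, unknown or untested is made for them only; others in the source may bear on it.

Measured compounds:
compound 1 `CCC(C)n1ncn(-c2ccc(N3CCN(c4ccc(OC[C@@H]5CO[C@@](Cn6cnc(C)n6)(c6ccc(Cl)cc6Cl)O5)cc4)CC3)cc2)c1=O`: 272 nM
compound 2 `CCC(C)n1ncn(-c2ccc(N3CCN(c4ccc(OC[C@@H]5CO[C@@](Cn6cc(C)nc6C)(c6ccc(Cl)cc6Cl)O5)cc4)CC3)cc2)c1=O`: 492 nM
compound 3 `CCC(C)n1ncn(-c2ccc(N3CCN(c4ccc(OC[C@@H]5CO[C@@](Cn6cc(C(F)(F)F)nc6C)(c6ccc(Cl)cc6Cl)O5)cc4)CC3)cc2)c1=O`: 441 nM

In a functional assay on HUVEC cells (Homo sapiens), read by scintillation counting and thymidine incorporation, with a stated time of 24 h (on this read-out lower numbers stand for stronger inhibition and higher numbers for weaker inhibition), compound 1 gives the lowest of the three numbers, but its two neighbours sit within the scatter of it. The step of a 1.8-fold higher number from compound 1 to compound 2 (0.26 log units; within the scatter) and the step of a 1.6-fold higher number from compound 1 to compound 3 (0.21 log units; within the scatter) both fall inside the usual spread, and the step of a 1.1-fold lower number from compound 2 to compound 3 (0.05 log units; within the scatter) is smaller still. On the numbers shown, changing the azole on a saturated chain carbon bound to a saturated ring carbon has so far moved this assay by less than repeated measurement would.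

Compound 4 `CCC(C)n1ncn(-c2ccc(N3CCN(c4ccc(OC[C@@H]5CO[C@@](Cn6cnnn6)(c6ccc(Cl)cc6Cl)O5)cc4)CC3)cc2)c1=O` is not yet measured. It differs from compound 1 in one place: 1H-tetrazol-1-yl in place of 3-methyl-1H-1,2,4-triazol-1-yl on a saturated chain carbon bound to a saturated ring carbon. The two measured steps away from compound 1 are the relevant comparisons, since each also replaces the same 3-methyl-1H-1,2,4-triazol-1-yl group at the same place, and neither left the scatter. The expectation for this assay is therefore a step from compound 1 to compound 4 of no more than the scatter, with the direction undetermined, though both earlier swaps gave somewhat higher numbers.

For compound 4 the expected value in this assay is 350 nM, within an estimated range of 150 nM to 850 nM, which corresponds to an expected step of a 1.3-fold higher number from compound 1 to compound 4 (0.11 log units; within the scatter).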

Compound 4, half-maximal inhibitory concentration: 73 nM
Compound 4: the middle estimate sits 4.8-fold (0.68 log units) above what was measured; measured number outside the range, below it.
By their numbers in this assay, from the lowest: compound 4; then compounds 1, 3 and 2 (each within the scatter of the next).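

In this assay, the azole on a saturated chain carbon bound to a saturated ring carbon can move the number beyond the scatter: 1H-tetrazol-1-yl in place of 3-methyl-1H-1,2,4-triazol-1-yl gives a 3.7-fold lower number from compound 1 to compound 4 (0.57 log units; beyond the scatter), whereas the steps among compound 1, compound 2 and compound 3 all stayed within it. The 1H-tetrazol-1-yl group also clears the scatter against both imidazole groups, with a 6.0-fold lower number from compound 3 to compound 4 (0.78 log units; beyond the scatter) and a 6.7-fold lower number from compound 2 to compound 4 (0.83 log units; beyond the scatter), which makes compound 4 the most potent of the four in this assay. No measured evidence available for the series bears on the reason for this drop.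

Still open, from the compounds shown here alone, is whether the lower number follows the additional ring nitrogen or the loss of the methyl, which a methyl-bearing tetrazole and a 1,2,4-triazole without its methyl at the same place would help to separate. Also open, going by these compounds, is whether an azole is needed here at all, which a simple amine or a nitrile on the same saturated chain carbon would test.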